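The source may report more compounds than this note shows. Statements on the series, on what has been measured and on what is new or still open speak of the compounds shown alone.

Compound 1 `CCOc1c(-c2occ(C)c2C(=O)O)ccc2c(CC)cccc12`: > 10 ug/mL
Compound 2 `CCOc1c(-c2occ(C)c2C(=O)OC)ccc2c(CC)cccc12`: 1.9 ug/mL
Compound 3 `CCc1cccc2c(OC)c(-c3occ(C)c3COC)ccc12`: > 10 ug/mL

All three have been tested in a functional assay on DU-145 cells (Homo sapiens) for cytotoxicity, read by MTT assay, with a stated time of 72 h; a higher number here means that more compound is needed for the effect, a lower number that less compound is needed. For compound 1 the result is a limit of the assay, > 10 ug/mL, not a number. Compound 2 gives 1.9 ug/mL. For the measured compounds named here, the one measured step, an at least 5.2-fold lower number from compound 1 to compound 2 (0.72 log units; beyond the scatter), is methyl in place of hydrogen on an oxygen next to a carbonyl group. For compound 3 the result is again only a limit, > 10 ug/mL. Compound 3 thus sits at the limit of > 10 ug/mL in this assay, at which 2 of the 3 values shown sit, alongside compound 1, while compound 2 is the only one of the three with a number in this assay.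

Compound 4 `CCOc1c(-c2occ(C)c2COC)ccc2c(CC)cccc12` has not yet been measured. It differs from compound 3 in one place: methyl in place of hydrogen on a saturated chain carbon bound to an oxygen on an aromatic ring. Going by the values given here, no measured step touches this place; the single measured step, from compound 1 to compound 2, changes the group on an oxygen next to a carbonyl group and so gives no guide here. Among the compounds with values here, with compound 3 at the limit and no step bearing on the change, the step that the limit leaves unreadable from compound 3 to compound 4 is expected to be none beyond the scatter. Compound 4 is therefore estimated at 15 ug/mL, within a range from 5 ug/mL to 50 ug/mL, most likely reported again only as a limit.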

Compound 4, concentration for half-maximal effect: > 10 ug/mL
Compound 4 gave a limit, no number; the forecaster's own chance of this, stated with the estimate: 65%; the middle value lies beyond the limit too.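

The new result bears mainly on the aromatic carbon that carries the methoxycarbonyl group of compound 2. Putting methoxymethyl there, with the rest of the molecule unchanged, gives an at least 5.2-fold higher number from compound 2 to compound 4 (0.72 log units; beyond the scatter) in this assay, so the measurable effect of compound 2 does not survive this replacement. Among the compounds shown, only the one with methoxycarbonyl at this carbon has a number, while those with carboxy or methoxymethyl there remain at the limit, and the steps from compound 3 to compound 4 and from compound 1 to compound 4 cannot be read, each joining two limits: the limit of > 10 ug/mL in this assay, at which 3 of the 4 values shown sit.

So the change from methoxy to ethoxy, the one this result was meant to probe, still has no readable effect, and how far compound 1, compound 3 and compound 4 lie beyond the limit also stays unknown. The compounds shown also leave open whether an amide or a longer ester chain at this aromatic carbon would keep a number as methoxycarbonyl does, and whether a propoxy group in place of ethoxy would change anything.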